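The source may hold more compounds than are shown below. What is called first, only, known or untested is meant among the compounds shown, and "the series" means these compounds.

Of the compounds shown here, two of the shared core have been measured. Compound 1 `CCOC(=O)[C@@H]1CC(=O)c2sccc2[C@H]1c1ccc(OC)cc1` carries a methoxy group on its phenyl ring, and in a physicochemical assay, read by spectrophotometry, with a stated time of 20 min, tested at 60 ug/mL (a lower number here means a weaker effect, a higher number a stronger effect of the compound at the concentration tested), compound 1 gives 20.3%, the lower of the two numbers recorded. Compound 2 `CCOC(=O)[C@@H]1CC(=O)c2sccc2[C@H]1c1ccc(OCC)cc1` carries an ethoxy group instead, and in this assay compound 2 gives 22.9%. For the measured compounds named here, the one step that connects them, a number 2.6 percentage points higher from compound 1 to compound 2 (within the scatter), shows that lengthening the alkoxy chain by a methyl in place of hydrogen on a saturated chain carbon bound to an oxygen on an aromatic ring leaves the read-out essentially where it was.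

Compound 3 `CCOC(=O)[C@@H]1CC(=O)c2sccc2[C@H]1c1ccc(OC)c(OC)c1` has not yet been measured in this assay. It differs from compound 1 by methoxy in place of hydrogen on an aromatic carbon. Going by the values given here, no measured step adds a group to the aromatic ring itself, so the only guidance is the step from compound 1 to compound 2, which stayed within the scatter. On that basis the step from compound 1 to compound 3 is expected to be small, a number 1.7 percentage points higher from compound 1 to compound 3 (within the scatter), in no clear direction. Compound 3 is therefore estimated at 22%, most likely between 12% and 33%.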

Compound 3, a percentage reported as activity, at one concentration (the size of the read-out at that concentration, not a potency): 20.9%
Compound 3: the middle estimate sits 1.1 percentage points above what was measured; the range from low to high includes it.
By their numbers in this assay, from the lowest: compounds 1, 3 and 2 (each within the scatter of the next).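

This is the first change shown on the aromatic ring itself rather than on the alkoxy chain. In this assay, placing methoxy in place of hydrogen on an aromatic carbon, ortho to a methoxy group and meta to a large group, gives a number 0.6 percentage points higher from compound 1 to compound 3 (within the scatter), so this added group of 2 heavy atoms leaves the read-out indistinguishable from that of compound 1, just as the chain change gave a number 2.6 percentage points higher from compound 1 to compound 2 (within the scatter). The compounds shown offer no information on why either change stays within the scatter.

On these data alone, all three compounds carry only alkoxy groups on the phenyl ring, so it remains open whether a hydroxyl, an amine, a chlorine or a carboxylic acid at this same aromatic carbon would shift the read-out in this assay beyond the scatter, or whether a longer chain such as butoxy on the oxygen would do so. Also open is whether changes elsewhere on the shared core would matter, for example a carboxylic acid or an amide in place of the ester, since every compound shown keeps that ester unchanged.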